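From cyclopropyl to tert-butyl on a shared core

A few compounds are considered here, and "the series" means these few. Any claim that something is new, unique, unknown or untested is made for them only; others in the source may bear on it.

Compound 1 `CC(C)c1cn2ccccc2c1S(=O)(=O)c1ccc(OCCCN2CCC(c3ccccc3)CC2)cc1`: 80.9 nM
Compound 2 `CC(C)(C)NCCCOc1ccc(S(=O)(=O)c2c(C3CC3)cn3ccccc23)cc1`: 66.5 nM

Among the compounds with values here, in a functional assay (aorta) with Rattus norvegicus as the target (a lower number here means a stronger inhibitor, a higher number a weaker inhibitor), compound 2 gives 66.5 nM, a value within the usual scatter of the one for compound 1. Compound 3 `CC(C)(C)NCCCOc1ccc(S(=O)(=O)c2c(C(C)(C)C)cn3ccccc23)cc1` keeps the rest of compound 2 but carries tert-butyl in place of cyclopropyl on an aromatic carbon. Within the data shown here, no measured pair isolates this change, so only a modest rise in the number is expected, possibly none beyond the scatter, and the estimated step is a 1.5-fold higher number from compound 2 to compound 3 (0.18 log units; within the scatter). For compound 3 the expected value is 100 nM, with an estimated range from 30 nM to 330 nM.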

Compound 3, half-maximal inhibitory concentration: 443 nM
Compound 3: the middle estimate sits 4.4-fold (0.65 log units) below what was measured, outside the stated range (above it).
By their numbers in this assay, from the lowest: compounds 2 and 1 (each within the scatter of the next); then compound 3.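

In this assay, within the data shown here, replacing cyclopropyl with tert-butyl on this aromatic carbon of the five-membered ring gives a 6.7-fold higher number from compound 2 to compound 3 (0.82 log units; beyond the scatter), the first sign that the group at this position matters, since compounds 1 and 2 differ in more than one place and isolated no such change. Nothing available accounts for this loss. The compounds shown leave open how isopropyl or methyl would fare at this position on the side chain of compound 2. They also leave open whether the same step would appear with the side chain of compound 1.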